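Chloro for bromo: the step from compound 3 to compound 4

The source may report more compounds than this note shows. Statements on the series, on what has been measured and on what is new or still open speak of the compounds shown alone.

Measured so far in an assay for inhibition of alkaline phosphatase, tissue-nonspecific isozyme (Homo sapiens), read by spectrophotometry, with stated times of 10 min and 20 min; on this read-out higher numbers stand for weaker inhibition and lower numbers for stronger inhibition:
- compound 1 `O=C1/C(=C/c2ccccc2)NS(=O)(=O)c2ccccc21` gives 660 nM.
- compound 3 `O=C1/C(=C/c2ccc(Br)cc2)NS(=O)(=O)c2ccccc21` gives 1430 nM.
- compound 2 `O=C1/C(=C/c2ccccc2Br)NS(=O)(=O)c2ccccc21` sits at a limit of the assay, > 200000 nM.

Compound 3 stands highest of the two numbers shown, and its one numeric neighbour is reached by a 2.2-fold higher number from compound 1 to compound 3 (0.34 log units; beyond the scatter), a modest rise. The other two steps, an at least 300-fold higher number from compound 1 to compound 2 (2.48 log units; beyond the scatter) and an at least 130-fold lower number from compound 2 to compound 3 (2.14 log units; beyond the scatter), are large and turn on where the bromo sits rather than on what halogen it is; one end of each is the limit (the limit of > 200000 nM in this assay, at which 1 of the 3 values shown sits).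

Compound 4 `O=C1/C(=C/c2ccc(Cl)cc2)NS(=O)(=O)c2ccccc21` follows from compound 3 by chloro in place of bromo on an aromatic carbon. Within the data shown here, no measured step exchanges one halogen for another at this place; the only step at this carbon is a 2.2-fold higher number from compound 1 to compound 3 (0.34 log units; beyond the scatter), and it is modest. The step from compound 3 to compound 4 is therefore expected to stay within the scatter, a 1.2-fold lower number from compound 3 to compound 4 (0.08 log units; within the scatter). For compound 4 the estimate in this assay is 1200 nM, with a range from 500 nM to 3000 nM.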

Compound 4, half-maximal inhibitory concentration: 250 nM
Estimate against measurement, compound 4: 4.8-fold (0.68 log units) above, and the stated range ends above it.
By their numbers in this assay, from the lowest: compound 4; then compound 1; then compound 3. At a limit, above all of these: compound 2.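

In this assay, among these compounds, the identity of the halogen at this carbon matters, a point the earlier compounds could not show: a 5.7-fold lower number from compound 3 to compound 4 (0.76 log units; beyond the scatter). Chloro also moves the number the opposite way from bromo relative to the unsubstituted compound, a 2.6-fold lower number from compound 1 to compound 4 (0.42 log units; beyond the scatter), so a halogen at this carbon can either raise or lower the number. The step of an at least 800-fold lower number from compound 2 to compound 4 (2.90 log units; beyond the scatter) starts from a limit of the assay and gives only a bound: the limit of > 200000 nM in this assay, at which 1 of the 4 values shown sits.

From the compounds shown here alone, whether the order among hydrogen, chloro and bromo extends to fluoro, methoxy or a carboxylic acid at this carbon remains open. Also open, going by these compounds, is whether chloro in place of the bromo of compound 2 would share that compound's limit.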